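The compounds below may be only part of what the source reports. "The series", "measured", "known", "first", "only" and "open" are said of these compounds alone.

Measured so far in an ADME assay on microsomes from liver (Homo sapiens) for metabolic stability, with a stated time of 10 min; on this read-out lower numbers stand for a less stable compound and higher numbers for a more stable compound:

- compound 1 `CC(C)S(=O)(=O)NC(=O)c1ccc(Nc2nc(NC3(c4ccc(Cl)cc4)CC3)nc(OCC(F)(F)F)n2)cc1`: 100%
- compound 2 `CC(C)NCCS(=O)(=O)NC(=O)c1ccc(Nc2nc(NC3(c4ccc(Cl)cc4)CC3)nc(OCC(F)(F)F)n2)cc1`: 89%
- compound 3 `CCCCCNc1nc(Nc2ccc([N+](=O)[O-])cc2)nc(OCC(F)(F)F)n1`: 74%

Among these three, compound 2 stands second, with compound 1 giving a higher number, the gap being beyond the scatter, and compound 3 giving a lower number, that gap also beyond the scatter. Within the data shown here, compound 1 and compound 2 share the whole core and differ only at the sulfonyl sulfur, and the change a number 11 percentage points lower from compound 1 to compound 2 (beyond the scatter) is the one measured step that bears on the next compound. Among the measured compounds shown here, compound 3 shares the core but has different groups at both ends, so its value shows only that this shared core can also sit lower in this assay.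

Compound 4 `CC(C)(C)OC(=O)NCCS(=O)(=O)NC(=O)c1ccc(Nc2nc(NC3(c4ccc(Cl)cc4)CC3)nc(OCC(F)(F)F)n2)cc1` is still unmeasured. It differs from compound 2 in one place: tert-butoxycarbonyl in place of isopropyl on an amine nitrogen. For the measured compounds named here, no measured pair shows this exact change, so the expectation rests on the single step from compound 1 to compound 2, which was modest. On that basis a change of similar or smaller size in this assay is expected, with a slight downward lean since compound 2 already sits a little under the top of the range. The estimated step is a number 5 percentage points lower from compound 2 to compound 4 (within the scatter), so compound 4 is expected to give about 84%, most likely between 62% and 100%.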

Compound 4, percent of the compound remaining: 92%
For compound 4 the middle estimate is 8 percentage points below the measured one; the measured number falls inside the stated range.
By their numbers in this assay, from the lowest: compound 3; then compounds 2, 4 and 1 (each within the scatter of the next, the first and the last beyond it).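

In this assay, tert-butoxycarbonyl (7 heavy atoms) in place of isopropyl (3 heavy atoms) on the amine nitrogen gives a number 3 percentage points higher from compound 2 to compound 4 (within the scatter), so at this position the read-out does not separate these two groups, even though the new group is the bigger one and brings hydrogen-bond acceptors. On the sulfonyl sulfur, 2-((tert-butoxycarbonyl)amino)ethyl in place of isopropyl gives a number 8 percentage points lower from compound 1 to compound 4 (within the scatter), while 2-(isopropylamino)ethyl there gave a number 11 percentage points lower from compound 1 to compound 2 (beyond the scatter), so only the second of these chains stands apart from isopropyl by more than the scatter, although the two chains cannot be told apart from each other. Nothing available explains these numbers.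

The compounds shown leave open how a free primary amine or an acetyl group on that nitrogen, or a longer chain on the sulfonyl sulfur, would read in this assay. They also leave open whether tert-butoxycarbonyl in place of isopropyl would read the same way on a different chain or core, as this change appears here in a single pair.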